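Removing one methyl from compound 3

A few compounds are considered here, and "the series" means these few. Any claim that something is new, unique, unknown or untested is made for them only; others in the source may bear on it.

- compound 1 `O=C1C=C(Nc2cccc(F)c2)C(=O)c2c1nc1n2[C@H]2OC[C@@H](O)[C@H]2OC1`: 6440 nM
- compound 2 `O=C1C=C(Nc2ccc(C(F)(F)F)cc2)C(=O)c2c1nc1n2[C@H]2OC[C@@H](O)[C@H]2OC1`: > 8000 nM (a limit of the assay, not a number)
- compound 3 `Cc1ccc(NC2=CC(=O)c3nc4n(c3C2=O)[C@H]2OC[C@@H](O)[C@H]2OC4)cc1C`: 2690 nM

In a functional assay on HeLa cells (Homo sapiens) for inhibition, read by sulforhodamine B assay (on this read-out higher numbers stand for weaker inhibition and lower numbers for stronger inhibition), compound 3 has the lower of the two true numbers. Compound 4 `Cc1ccc(NC2=CC(=O)c3nc4n(c3C2=O)[C@H]2OC[C@@H](O)[C@H]2OC4)cc1` differs from it at one place: hydrogen in place of methyl on an aromatic carbon, so 3,4-dimethylphenyl becomes 4-methylphenyl.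

For the measured compounds named here, no measured step isolates this methyl. The closest evidence comes from swapping the whole group on the amine nitrogen: a 2.4-fold lower number from compound 1 to compound 3 (0.38 log units; beyond the scatter) and an at least 2.9-fold lower number from compound 2 to compound 3 (0.47 log units; beyond the scatter). Both swaps were modest, so removing one methyl is expected to raise the number only slightly, without clearly passing the scatter. The estimate for this assay means a 1.3-fold higher number from compound 3 to compound 4 (0.11 log units; within the scatter). Compound 4 is expected at 3500 nM, within an estimated range of 1800 nM to 6500 nM.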

Compound 4, half-maximal inhibitory concentration: 3860 nM
Compound 4: middle estimate off by 1.1-fold (0.04 log units), on the low side, within the range that was stated.
By their numbers in this assay, from the lowest: compounds 3, 4 and 1 (each within the scatter of the next, the first and the last beyond it). At a limit, above all of these: compound 2.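

With a 1.4-fold higher number from compound 3 to compound 4 (0.16 log units; within the scatter) and a 1.7-fold lower number from compound 1 to compound 4 (0.22 log units; within the scatter) in this assay the methyl that leaves carries little on its own, and 4-methylphenyl cannot be told from 3-fluorophenyl. Methyl in place of trifluoromethyl does pass the scatter, with an at least 2.0-fold lower number from compound 2 to compound 4 (0.31 log units; beyond the scatter) as a floor rather than a full measure. Compound 2 sits at a limit, not at a number: the limit of > 8000 nM in this assay, at which 1 of the 4 values shown sits.

Going by these compounds, whether an amine or a methoxy group in place of the remaining methyl would shift the number stays open. So does how far compound 2 truly lies from compound 4.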